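A few compounds are considered here, and "the series" means these few. Any claim that something is new, unique, unknown or untested is made for them only; others in the source may bear on it.

Of the compounds shown here, two have been measured here, and both carry a methyl ester on a shared core with an amide-linked chain ending in a thioether to an aromatic ring. Compound 1 `COC(=O)c1oc2cccc(Cl)c2c1NC(=O)CCSc1ccccn1` and compound 2 `COC(=O)c1sccc1NC(=O)CSc1cccc(OC)c1` were each tested in an assay on H9c2 cells for inhibition of tumor necrosis factor receptor superfamily member 6 (Rattus norvegicus), with stated times of 30 min and 6 h; a lower number here means that less compound is needed, a higher number that more compound is needed for the effect. In this assay compound 1 gives 631 nM, and compound 2 gives 575 nM. The two numbers lie within the scatter of each other, so neither compound can be said to stand apart from the other; compound 2 simply happens to show the lower of the two values.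

Compound 3 `COC(=O)c1sccc1NC(=O)CSc1ccccc1` has not yet been measured. Compound 3 differs from compound 2 in one place: hydrogen in place of methoxy on an aromatic carbon. Among the measured compounds shown here, no measured pair here shows a comparable change, so nothing is known about how large such a step tends to be in this assay. Given that, the step from compound 2 to compound 3 in this assay is expected to be small, a 1.2-fold higher number from compound 2 to compound 3 (0.09 log units; within the scatter), with no direction beyond the scatter. Compound 3 is therefore estimated at 700 nM, within a range from 300 nM to 1600 nM.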

Compound 3, half-maximal effective concentration: 794 nM
The estimate for compound 3 lay 1.1-fold (0.05 log units) below the measured number, within the range that was stated.
By their numbers in this assay, from the lowest: compounds 2, 1 and 3 (each within the scatter of the next).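

Among the compounds shown here, compound 2 and compound 3 form the first pair here that differs in only one place, so a single change can now be read in this assay: hydrogen in place of methoxy on an aromatic carbon, meta to a large group, gives (a 1.4-fold higher number from compound 2 to compound 3 (0.14 log units; within the scatter)). At this position on the six-membered aromatic ring, the methoxy group and plain hydrogen therefore cannot be told apart in this measurement, even though the exchange removes two heavy atoms and one hydrogen-bond acceptor. No measured evidence offers an explanation for this result.

Going by these compounds, it remains open whether a different group at this position, such as an amine, a carboxylic acid or a longer chain, would give a step beyond the scatter. This single pair also leaves open whether the same exchange of methoxy for hydrogen would give a similarly small step elsewhere on the ring or on the core of compound 1.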